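Fluoro for methyl on the pendant phenyl ring: compound 4

The compounds below may be only part of what the source reports. "The series", "measured", "known", "first", "only" and "open" are said of these compounds alone.

Measured so far in a functional assay on MCF7 cells (Homo sapiens) for cytotoxicity, read by MTT assay, with a stated time of 72 h; on this read-out higher numbers stand for weaker inhibition and lower numbers for stronger inhibition:
compound 1 `Cc1ccc(-c2ccc(C(=O)Nc3ccc(Oc4ccnc5[nH]ccc45)cc3)nc2)cc1` — > 10000 nM
compound 2 `O=C(Nc1ccc(Oc2ccnc3[nH]ccc23)cc1)c1cc(-c2ccc(C(F)(F)F)cc2)ccn1` — > 10000 nM
compound 3 `Cc1ccc(-c2ccc(C(=O)Nc3ccc(Oc4ccnc5[nH]ccc45)c(F)c3)nc2)cc1` — 8020 nM

In this assay compound 1 gives > 10000 nM, which is a limit of the assay and not a number. In this assay compound 2 likewise gives > 10000 nM, a limit. Among the compounds with values here, compound 3 holds the only measured number; the step of an at least 1.2-fold lower number from compound 1 to compound 3 (0.09 log units; that floor lies within the scatter) runs from a limit and its floor is within the scatter, so it cannot be called a real gain (the limit of > 10000 nM in this assay, at which 2 of the 3 values shown sit).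

Compound 4 `O=C(Nc1ccc(Oc2ccnc3[nH]ccc23)c(F)c1)c1ccc(-c2ccc(F)cc2)cn1` differs from compound 3 by fluoro in place of methyl on an aromatic carbon. Within the data shown here, no measured step carries this change; compound 2, which bears trifluoromethyl at the same place, sits at the limit, and compound 3 itself lies close to it. Compound 4 is therefore expected to give about 9000 nM in this assay, with an expected range of 4000 nM to 25000 nM, meaning an expected step of a 1.1-fold higher number from compound 3 to compound 4 (0.05 log units; within the scatter). The upper end of this expected range reaches past the limit of the assay.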

Compound 4, half-maximal inhibitory concentration: > 10000 nM
Compound 4: only a limit was reported (the forecaster's own chance of this, stated with the estimate: 40%); at least 1.1-fold (0.04 log units) between middle value and limit.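

In this assay the change from 4-methylphenyl to 4-fluorophenyl gives an at least 1.2-fold higher number from compound 3 to compound 4 (0.09 log units; that floor lies within the scatter), which runs to a limit and has a floor within the scatter, so it cannot be called a real weakening. Compound 4 gives > 10000 nM, which is a limit of the assay and not a number. Fluoro at this position therefore yields no number to set against compound 3, and the series stays almost wholly at one limit: the limit of > 10000 nM in this assay, at which 3 of the 4 values shown sit.

From the compounds shown here alone, whether an amine or a carboxylic acid at this position would give a number in this assay stays open. Going by these compounds, how far compound 4 lies from compound 3 also stays open.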